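This account rests on a few compounds, and the source may have more. Where it says the series, first, only, none or still open, it means among the compounds named here.

Measured so far in a functional assay on WM 266-4 cells (Homo sapiens) for antiproliferative activity, read by MTT assay, with a stated time of 48 h; a lower number here means a stronger inhibitor of growth, a higher number a weaker inhibitor of growth:

compound 1, `S=C(Nc1ccccc1)N1N=C(c2ccc(Br)cc2)CC1c1ccc2c(c1)OCCO2`: 870 nM
compound 2, `COc1ccccc1C1=NN(C(=S)Nc2ccccc2)C(c2ccc3c(c2)OCCO3)C1`: 25800 nM
compound 3, `S=C(Nc1ccccc1)N1N=C(c2cccc(Cl)c2)CC1c1ccc2c(c1)OCCO2`: > 200000 nM, a limit of the assay and not a number.

Compound 1 gives the lowest of the two numbers in this assay; the nearest is compound 2, with a 30-fold higher number from compound 1 to compound 2 (1.47 log units; beyond the scatter). Compound 3 sits at the assay limit, (the limit of > 200000 nM in this assay, at which 1 of the 3 values shown sits), so its gap to compound 1 is at least an at least 220-fold higher number from compound 1 to compound 3 (2.36 log units; beyond the scatter). Between the two weaker compounds, an at least 7.7-fold higher number from compound 2 to compound 3 (0.88 log units; beyond the scatter).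

Compound 4, `S=C(Nc1ccccc1)N1N=C(c2ccc(Cl)c(Cl)c2)CC1c1ccc2c(c1)OCCO2`, is not yet measured in this assay. Its change from compound 1 is 3,4-dichlorophenyl in place of 4-bromophenyl on a carbon with a double bond to nitrogen.

Both measured steps away from the 4-bromophenyl of compound 1 bear on this: a 30-fold higher number from compound 1 to compound 2 (1.47 log units; beyond the scatter) and an at least 220-fold higher number from compound 1 to compound 3 (2.36 log units; beyond the scatter), each large and each toward weaker growth inhibition. The entering 3,4-dichlorophenyl shares its 3-chloro substitution with the 3-chlorophenyl of compound 3, which lies at the limit (the limit of > 200000 nM in this assay, at which 1 of the 3 values shown sits), while also carrying a halogen at the 4-position as in compound 1. A rise beyond the scatter is therefore expected, though with wide uncertainty on its size.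

For compound 4 the expected value in this assay is 8000 nM, within 1200 nM to 120000 nM. This estimate corresponds to a 9.2-fold higher number from compound 1 to compound 4 (0.96 log units; beyond the scatter).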

Compound 4, concentration for 50% growth inhibition: 58700 nM
Beside the measured number, compound 4's estimate is 7.3-fold (0.87 log units) below it; measured number inside the range.
By their numbers in this assay, from the lowest: compound 1; then compound 2; then compound 4. At a limit, above all of these: compound 3.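

In this assay the 3,4-dichlorophenyl does not hold the level of the 4-bromophenyl (a 67-fold higher number from compound 1 to compound 4 (1.83 log units; beyond the scatter)), and it lands much closer to the 2-methoxyphenyl (a 2.3-fold higher number from compound 2 to compound 4 (0.36 log units; beyond the scatter)), so a chlorine on the ring that also carries the 4-halogen pattern of compound 1 is not enough to keep that level at this carbon with a double bond to nitrogen. Chloro in place of hydrogen on an aromatic carbon turns the 3-chlorophenyl into the 3,4-dichlorophenyl and gives a measurable number (an at least 3.4-fold lower number from compound 3 to compound 4 (0.53 log units; beyond the scatter)), which shows that the second chloro moves the series off the assay limit without approaching compound 1. Compound 3 holds a limit of the assay and not a number, so that step is only a bound: the limit of > 200000 nM in this assay, at which 1 of the 4 values shown sits.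

Going by these compounds, whether the standing of compound 1 belongs to bromine itself or to a single group on the ring stays open, and a 4-chlorophenyl, a 4-methoxyphenyl or a 3-bromophenyl would separate these readings. An unsubstituted phenyl at the same carbon would give the series a reference for every step read so far.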